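This account rests on a few compounds, and the source may have more. Where it says the series, first, only, none or still open, it means among the compounds named here.

Compound 1 `Nc1nc(Cl)c(-c2ccccn2)c(N[C@@H]2C[C@H](CO)[C@@H](O)[C@H]2O)n1`: in an ADME assay on cells (Homo sapiens) for cytotoxicity, read by polymerase chain reaction, with a stated time of 3 days (a higher number here means that more compound is tolerated, a lower number that less compound is tolerated), compound 1 gives > 25000 nM, which is a limit of the assay rather than a number.
Compound 2 `Nc1nc(Cl)c(-c2ccco2)c(N[C@@H]2C[C@H](CO)[C@@H](O)[C@H]2O)n1`: in this assay compound 2 gives > 25000 nM, again a limit of the assay.
Compound 3 `Cc1nc(NC(C)(C)C)nc(N[C@@H]2C[C@H](CO)[C@@H](O)[C@H]2O)c1-c1nc2ccccc2s1`: in this assay compound 3 gives 12000 nM.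

Among these three, compound 3 is the only one with an actual number; the other two values are limits, as summed up by the limit of > 25000 nM in this assay, at which 2 of the 3 values shown sit. Compound 4 `Cc1nc(NCc2ccsc2)nc(N[C@@H]2C[C@H](CO)[C@@H](O)[C@H]2O)c1-c1nc2ccccc2s1` is the compound still to be measured. It differs from compound 3 in one place: (thiophen-3-yl)methyl in place of tert-butyl on a nitrogen on an aromatic ring. Going by the values given here, the only measured step, a step that the two limits leave unreadable from compound 1 to compound 2, concerns another part of the shared core and cannot be read in size, so no measured step bears directly on the change from compound 3 to compound 4. With nothing to point in either direction, there is no reason to expect a step beyond the usual scatter in this assay, up or down. The expectation for compound 4 in this assay is therefore 10000 nM, within a range from 4000 nM to 25000 nM. The step this estimate implies is a 1.2-fold lower number from compound 3 to compound 4 (0.08 log units; within the scatter), and it is held as an expectation only until compound 4 has been measured.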

Compound 4, half-maximal cytotoxic concentration: 6000 nM
The estimate for compound 4 lay 1.7-fold (0.22 log units) above the measured number; the range from low to high includes it.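

Putting (thiophen-3-yl)methyl in place of tert-butyl on a nitrogen on an aromatic ring gives a 2.0-fold lower number from compound 3 to compound 4 (0.30 log units; within the scatter). In this assay, this position therefore accepts a swap from a group with no ring to one with a five-membered aromatic ring and more heavy atoms, without a step beyond the scatter. This is also the first step in the set that can be read in size, as the earlier step joins two compounds whose values are limits of the assay rather than numbers: the limit of > 25000 nM in this assay, at which 2 of the 4 values shown sit.

The compounds shown leave open whether this tolerance extends to other groups on the same nitrogen, such as a longer alkyl chain, a benzyl group, or a chain ending in an amine or a carboxylic acid, any of which might give a step beyond the scatter from compound 3. Going by these compounds alone, with only one readable step at this position, they also cannot separate what the thiophene ring contributes from what the methylene link contributes, and they offer no measured property that would explain the step.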